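A few compounds are considered here, and "the series" means these few. Any claim that something is new, unique, unknown or untested is made for them only; others in the source may bear on it.

In a functional assay on IGROV-1 cells (Homo sapiens) for inhibition, read by sulforhodamine B assay, with a stated time of 48 h (on this read-out lower numbers stand for stronger inhibition of growth and higher numbers for weaker inhibition of growth), compound 1 `COc1cc(-c2nn(-c3cccc(NC(=O)c4ccc(Cl)c(C(F)(F)F)c4)c3)cc2-c2ccncc2)ccc1Cl` gives > 32500 nM, which is a limit of the assay rather than a number. Compound 1 stands at the limit of > 32500 nM in this assay, at which 1 of the 2 values shown sits. Compound 2 `O=C(Nc1cccc(-n2cc(-c3ccncc3)c(-c3ccc(Cl)c(O)c3)n2)c1)Nc1cc(C(F)(F)F)cc(C(F)(F)F)c1` gives 3550 nM in this assay. Compound 3 `COc1cc(-c2nn(-c3cccc(NC(=O)Nc4ccc(Cl)c(C(F)(F)F)c4)c3)cc2-c2ccncc2)ccc1Cl` differs from compound 1 by (4-chloro-3-(trifluoromethyl)phenyl)amino in place of 4-chloro-3-(trifluoromethyl)phenyl on a carbonyl carbon. Among the compounds with values here, no step between measured compounds is known here, and compound 1 itself gives only a limit. The step of an at least 3.2-fold lower number from compound 1 to compound 3 (0.51 log units; beyond the scatter) is expected to run toward stronger inhibition of growth, of uncertain size. Compound 3 is estimated at 10000 nM in this assay, with a range from 3000 nM to 40000 nM.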

Compound 3, concentration for total growth inhibition: 4220 nM
Compound 3: the middle estimate sits 2.4-fold (0.37 log units) above what was measured; the range from low to high includes it.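

Within the data shown here, putting (4-chloro-3-(trifluoromethyl)phenyl)amino in place of 4-chloro-3-(trifluoromethyl)phenyl on the carbonyl carbon gives the first readable step at this position: in this assay it brings an at least 7.7-fold lower number from compound 1 to compound 3 (0.88 log units; beyond the scatter). With this change, compound 3 gives a measured number, 4220 nM. Compound 1 gives only a limit, so the full size of the step stays unknown: the limit of > 32500 nM in this assay, at which 1 of the 3 values shown sits.

The compounds shown leave open whether the amino hydrogen matters, and whether a methylamino group, a methylene or an ether oxygen in that place would serve as the amino group does.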